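Cytotoxicity notes on the imidazolylsulfanyl pyrimidine series

The source may report more compounds than this note shows. Statements on the series, on what has been measured and on what is new or still open speak of the compounds shown alone.

Measured compounds:
- compound 1, `Cn1ccnc1Sc1cnc(-c2ccc(N)cc2)nc1-c1ccccc1O`: 80100 ug/mL
- compound 2, `Cn1ccnc1Sc1cnc(-c2ccccc2)nc1-c1ccccc1O`: 120000 ug/mL
- compound 3, `COc1ccc(O)c(-c2ncncc2Sc2nccn2C)c1`: 618000 ug/mL

In an ADME assay on MDCK cells (Canis lupus familiaris) for cytotoxicity (a higher number here means that more compound is tolerated, a lower number that less compound is tolerated), compound 2 gives 120000 ug/mL, the second highest of the three numbers. Compound 1 lies closest: the step of a 1.5-fold higher number from compound 1 to compound 2 (0.18 log units; within the scatter) stays within the scatter. Within the data shown here, compound 3 lies furthest, with a value that stands beyond the scatter above compound 2; compound 3 differs from compound 2 in more than one place, so no single step is drawn between them.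

Compound 4, `Cc1ncc(Sc2nccn2C)c(-c2ccccc2O)n1`, is not yet measured in this assay. It differs from compound 2 by methyl in place of phenyl on an aromatic carbon. Among the measured compounds shown here, no measured step covers this change directly; the only step in hand, the removal of amino from compound 1 to compound 2, is within the scatter and sits elsewhere on the molecule. The values of compound 2 and compound 3 show that a compound without an aryl group at that carbon can carry a higher number, but compound 3 also carries a methoxy group, so the two values do not isolate the phenyl.

For compound 4, a step of a 1.7-fold higher number from compound 2 to compound 4 (0.22 log units; within the scatter) is expected, most likely within the scatter or modestly upward, giving an estimated 200000 ug/mL, with a range from 100000 ug/mL to 500000 ug/mL.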

Compound 4, half-maximal cytotoxic concentration: 577000 ug/mL
The estimate for compound 4 lay 2.9-fold (0.46 log units) below the measured number; measured number above the stated range.
By their numbers in this assay, from the lowest: compounds 1 and 2 (each within the scatter of the next); then compounds 4 and 3 (each within the scatter of the next).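

Among these compounds, at the aromatic carbon between two ring nitrogen atoms, methyl in place of phenyl is the first single change to move the number in this assay beyond the scatter (a 4.8-fold higher number from compound 2 to compound 4 (0.68 log units; beyond the scatter)). Methyl in place of 4-aminophenyl at the same carbon points the same way (a 7.2-fold higher number from compound 1 to compound 4 (0.86 log units; beyond the scatter)), whereas removing the amino group alone stays within the scatter (a 1.5-fold higher number from compound 1 to compound 2 (0.18 log units; within the scatter)). Among compounds 1, 2 and 4, the clear difference therefore follows the aromatic ring at this carbon, not the amino group on it, and more compound is tolerated with methyl there.

From the compounds shown here alone, whether an ethyl group, a longer chain, an amine or a carboxylic acid at this carbon would behave like methyl or like phenyl remains open. Nothing available explains why the number rises with this change.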